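The compounds below may be only part of what the source reports. "The series", "measured", "known", "first", "only" and "open" are said of these compounds alone.

Compound 2 `NC(=O)c1c(NC(=O)c2ccccc2F)sc2c1CCN(C(=S)Nc1ccccc1Cl)C2` is examined in a functional assay on HeLa cells (Homo sapiens) for antiproliferative activity, with a stated time of 24 h (a lower number here means a stronger inhibitor, a higher number a weaker inhibitor), alongside compound 1 `NC(=O)c1c(NC(=O)c2ccccc2F)sc2c1CCN(Cc1c(Cl)cccc1Cl)C2`, which shares its core. In this assay compound 1 gives 33000 nM, and compound 2 gives 19400 nM. Going by the values given here, the only step measured between them, a 1.7-fold lower number from compound 1 to compound 2 (0.23 log units; within the scatter), concerns the substituent on the amine nitrogen in the ring and stays within the scatter, so the two numbers cannot be ordered.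

Compound 3 `COc1ccccc1C(=O)Nc1sc2c(c1C(N)=O)CCN(C(=S)Nc1ccccc1Cl)C2` differs from compound 2 at a different place: methoxy in place of fluoro on an aromatic carbon. Among the compounds with values here, no measured step touches this position, so nothing among the present compounds speaks for a change in either direction, and the expectation is a step within the scatter. Compound 3 is therefore estimated to give 20000 nM in this assay, with a likely range from 8000 nM to 50000 nM, which corresponds to an expected step of a 1.0-fold higher number from compound 2 to compound 3 (0.01 log units; within the scatter).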

Compound 3, half-maximal inhibitory concentration: > 50000 nM
Compound 3: no number, only a limit; the forecaster's own chance of this, stated with the estimate: 10%; middle value at least 2.5-fold (0.39 log units) away from the limit.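

Methoxy in place of fluoro on this aromatic carbon, ortho to a large group, gives an at least 2.5-fold higher number from compound 2 to compound 3 (0.41 log units; beyond the scatter) in this assay, so this position is not indifferent to the change. The earlier step concerned the substituent on the amine nitrogen in the ring and stayed within the scatter, which makes this the first step among the compounds shown to go beyond it. Its full size cannot be read, since the value of compound 3 is a limit of the assay and not a number: the limit of > 50000 nM in this assay, at which 1 of the 3 values shown sits.

The compounds shown leave open whether the step follows from the arrival of methoxy or the departure of fluoro, a question that a hydrogen, a chloro group or an ethoxy group on this carbon would bear on. Also open, from the compounds shown here alone, is whether the same change gives a similar step with the substituent of compound 1 on the amine nitrogen in the ring.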